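The source may hold more compounds than are shown below. What is called first, only, known or untested is meant among the compounds shown, and "the series" means these compounds.

Measured so far:
compound 1, `CC(C)C[C@H](NC(=O)c1ccc(Cl)c(Cl)c1)C(=O)N[C@H]1CCN(Cc2ccc(OCCCN(C)C)cc2)C1`: 126 nM
compound 2, `CC(C)[C@H](NC(=O)c1ccc(Cl)c(Cl)c1)C(=O)N[C@H]1CCN(Cc2ccc(OCCCN(C)C)cc2)C1`: 794 nM
compound 3, `CN(C)CCCOc1ccc(CN2CC[C@H](NC(=O)CNC(=O)c3ccc(Cl)c(Cl)c3)C2)cc1`: < 10000 nM

In an assay on HEK293 cells for binding affinity to Urotensin-2 receptor (Homo sapiens), read by radioligand binding (a higher number here means a weaker inhibitor, a lower number a stronger inhibitor), compound 1 gives 126 nM and compound 2 gives 794 nM. For compound 3 the value < 10000 nM is a limit of this assay, not a number, so compound 3 stands only at a limit on the numbers shown; the steps a step that the limit leaves unreadable from compound 1 to compound 3 and a step that the limit leaves unreadable from compound 2 to compound 3 are therefore not readable, as the limit of < 10000 nM in this assay, at which 1 of the 3 values shown sits, shows.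

The unmeasured compound 4, `CN(C)CCCOc1ccc(CN2CC[C@H](NC(=O)[C@H](CCCN)NC(=O)c3ccc(Cl)c(Cl)c3)C2)cc1`, differs from compound 3 by 3-aminopropyl in place of hydrogen on a saturated chain carbon bound to an amide-type nitrogen and a carbonyl carbon. Among the measured compounds shown here, the only readable step, a 6.3-fold higher number from compound 1 to compound 2 (0.80 log units; beyond the scatter), shows that the side chain on this carbon matters, with the larger isobutyl giving the lower number. Compound 4 restores a side chain of four heavy atoms at that position, so a number rather than a limit is expected, with the step that the limit leaves unreadable from compound 3 to compound 4 estimated as a move to stronger inhibition. Compound 4 is estimated at 500 nM, within 100 nM to 5000 nM.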

Compound 4, inhibition constant: < 10000 nM
Compound 4: a limit, no number; the forecaster's own chance of this, stated with the estimate: 20%; the middle value lies beyond the limit too.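

In this assay compound 4 gives < 10000 nM, a limit and not a number. Among the compounds shown here, no new step from compound 1, compound 2 or compound 3 to compound 4 can be read: the limit of < 10000 nM in this assay, at which 2 of the 4 values shown sit. The compounds shown leave open how 3-aminopropyl in place of hydrogen on this carbon changes the affinity.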